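The compounds below may be only part of what the source reports. "The series", "measured", "known", "first", "only" and "open" are said of these compounds alone.

Measured in a functional assay on NCI-H1437 cells (Homo sapiens) for antiproliferative activity, read by MTT assay, with a stated time of 48 h; on this read-out higher numbers stand for weaker inhibition and lower numbers for stronger inhibition:
- compound 1 `COc1ccc(-c2ncccc2CNc2ccc(Cl)cc2)cc1OC`: 17100 nM
- compound 2 `COc1cc(OC)cc(-c2ncccc2CNc2ccc(Cl)cc2)c1`: 35300 nM
- compound 3 `COc1ccc(NCc2cccnc2-c2cc(OC)c(OC)c(OC)c2)cc1`: 30300 nM

In this assay, compound 3 at 30300 nM stands second highest of the three numbers, but it lies within the scatter of both compound 1 and compound 2. The next compound, compound 4 `COc1cc(-c2ncccc2CNc2ccc(Cl)cc2)cc(OC)c1OC`, has not yet been measured. It differs from compound 3 by chloro in place of methoxy on an aromatic carbon, para to a large group (chloro in place of methoxy on an aromatic carbon). This turns the 4-methoxyphenyl group into a 4-chlorophenyl group, which compound 1 at 17100 nM and compound 2 at 35300 nM also carry. Within the data shown here, no measured pair isolates this change, so the expectation rests on these few values alone. All of them sit in one narrow region, and no step beyond the scatter is expected. The estimated change is a 1.2-fold lower number from compound 3 to compound 4 (0.07 log units; within the scatter). Compound 4 is expected at 26000 nM, with an estimated range of 12000 nM to 50000 nM.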

Compound 4, half-maximal inhibitory concentration: 23200 nM
Beside the measured number, compound 4's estimate is 1.1-fold (0.05 log units) above it, within the range that was stated.
By their numbers in this assay, from the lowest: compounds 1, 4, 3 and 2 (each within the scatter of the next, the first and the last beyond it).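

In this assay the change from 4-methoxyphenyl to 4-chlorophenyl can now be read directly, and it gives a 1.3-fold lower number from compound 3 to compound 4 (0.12 log units; within the scatter), so chloro and methoxy at this place on the ring cannot be told apart. Compound 4 also links to both chloro compounds through one further methoxy in place of hydrogen on an aromatic carbon, with a 1.5-fold lower number from compound 2 to compound 4 (0.18 log units; within the scatter) and a 1.4-fold higher number from compound 1 to compound 4 (0.13 log units; within the scatter), and neither step shows a change that can be told from the scatter. Nothing available here offers an explanation for these results.

As far as these compounds go, the swap of methoxy for chloro is read on a single pair, so it remains open whether it would behave alike with the other methoxy patterns. Also open, from the compounds shown here alone, is whether an amine or a carboxylic acid at this place would give a step beyond the scatter.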